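Removing the benzyl group from compound 2

The source may report more compounds than this note shows. Statements on the series, on what has been measured and on what is new or still open speak of the compounds shown alone.

Compound 1 `COc1ccc(-c2cc3c(OC)cc(OC)cc3n(CCCC#N)c2=O)cc1`: 10000 nM
Compound 2 `COc1ccc(-c2cc3c(OC)cc(OC)cc3n(CC(=O)OCc3ccccc3)c2=O)cc1`: 10000 nM

Both values come from a functional assay on A549 cells (Homo sapiens) for cytotoxicity, read by colorimetric assay and MTT assay; a higher number here means a weaker inhibitor, a lower number a stronger inhibitor. Within the data shown here, on these numbers, compound 2 stands level with compound 1, its only neighbour so far. The two share a core and differ in one chain on an aromatic nitrogen, where benzyloxycarbonyl takes the place of 2-cyanoethyl.

The next structure is compound 3 `COc1ccc(-c2cc3c(OC)cc(OC)cc3n(CC(=O)O)c2=O)cc1`, which carries one further change at the end of that chain: hydrogen in place of benzyl on an oxygen next to a carbonyl group. Hydrogen takes the place of benzyl on an oxygen next to a carbonyl group, so benzyloxycarbonyl becomes carboxy.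

Among the measured compounds shown here, only one measured step bears on this, and it is a different swap at the same chain end: no change at the digits printed from compound 1 to compound 2 (within the scatter). For the measured compounds named here, that is a single comparison, and no measured pair shows the loss of benzyl itself, so the evidence is thin. Going by the values given here, still, with compound 2 at 10000 nM and no movement in that step, no shift beyond the scatter is expected in this assay.

The expected change is no change at the digits printed from compound 2 to compound 3 (within the scatter).

For compound 3 the estimated value is 10000 nM, with an expected range from 3500 nM to 30000 nM.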

Compound 3, half-maximal inhibitory concentration: 10000 nM
Compound 3: middle estimate and measured number agree at the digits printed; the range from low to high includes it.
By their numbers in this assay, from the lowest: compounds 1, 2 and 3 (each within the scatter of the next).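

In this assay, the change of benzyl to hydrogen on an oxygen next to a carbonyl group now has a measured outcome: no change at the digits printed from compound 2 to compound 3 (within the scatter), so the benzyl group, with its six-membered aromatic ring, can leave this chain end without any shift in the number. The carboxy group can also be set directly against the 2-cyanoethyl chain, with no change at the digits printed from compound 1 to compound 3 (within the scatter), so three different groups on the aromatic nitrogen now read alike in this assay. Nothing available here explains why these chain ends give the same reading.

From the compounds shown here alone, it remains open what an amine or an amide at the chain end would give, what a longer chain would give, and whether a plain hydrogen on the aromatic nitrogen, with no chain at all, would read the same. Going by these compounds, all three compounds share one number, so it is also open whether these chain ends would still read alike on a core that gives a lower value.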